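The source may report more compounds than this note shows. Statements on the series, on what has been measured and on what is new or still open speak of the compounds shown alone.

In a functional assay on K562 cells (Homo sapiens) for antiproliferative activity, read by MTT assay, with a stated time of 72 h (a lower number here means a stronger inhibitor, a higher number a weaker inhibitor), compound 1 `O=C1NC(=S)S/C1=C\C1=Cc2ccccc2OC1` gives 55300 nM. Compound 2 `O=C(O)CN1C(=O)/C(=C/C2=Cc3ccccc3OC2)SC1=S` reaches only a limit of the assay, > 100000 nM. Compound 3 `CC1Oc2ccc(Br)cc2C=C1/C=C1\SC(=S)NC1=O` gives 31600 nM.

Compound 2 differs from compound 1 by a single change, (carboxymethyl in place of hydrogen on an amide-type nitrogen in a ring). That change gave an at least 1.8-fold higher number from compound 1 to compound 2 (0.25 log units; that floor lies within the scatter); the size of the step is known only as a floor because of the limit of > 100000 nM in this assay, at which 1 of the 3 values shown sits. Compound 3 carries a different core from compound 1, and how the two cores differ is not broken down here. The unmeasured compound 4 `CC1Oc2ccc(Br)cc2C=C1/C=C1\SC(=S)N(CC(=O)O)C1=O` stands to compound 3 as compound 2 stands to compound 1: carboxymethyl in place of hydrogen on an amide-type nitrogen in a ring. The place of the change reads the same in both pairs, so it is the same change. Among the compounds with values here, only this one earlier example of the change is known, and it rests on a limit. From compound 3 the step is expected to be a 2.5-fold higher number from compound 3 to compound 4 (0.40 log units; beyond the scatter), judged from the earlier step of an at least 1.8-fold higher number from compound 1 to compound 2 (0.25 log units; that floor lies within the scatter). Compound 4 is therefore expected at about 80000 nM, with a likely range from 35000 nM to 200000 nM, and a fair chance that only a limit is reported.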

Compound 4, half-maximal inhibitory concentration: > 50000 nM
Compound 4 was reported as a limit; the forecaster's own chance of this, stated with the estimate: 45%; the middle value lies beyond the limit too.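

Compound 4 reaches only a limit of the assay, > 50000 nM. In this assay, carboxymethyl in place of the amide hydrogen on the ring nitrogen therefore gives a step known only as a floor, an at least 1.5-fold higher number from compound 3 to compound 4 (0.19 log units; that floor lies within the scatter). On neither core does the change bring a lower number, but the true size of the step is unknown on both, so these results do not show that it carries over by the same amount: the same change on two cores in this assay, an at least 1.8-fold higher number (0.25 log units; that floor lies within the scatter) from compound 1 to compound 2 and an at least 1.5-fold higher number (0.19 log units; that floor lies within the scatter) from compound 3 to compound 4; the limit leaves it open whether they differ

The compounds shown leave open how large the step really is on either core, since a compound beyond the limit has no exact value to compare. They also leave open whether the outcome depends on the carboxylic acid at the end of the chain, which a methyl group, a methyl ester of the same chain or a longer chain ending in an amine on that nitrogen could help to separate.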